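Piperidin-4-yl for pyridin-2-yl: a working note

This account rests on a few compounds, and the source may have more. Where it says the series, first, only, none or still open, it means among the compounds named here.

Compound 1 `COc1ccc(Cl)c([C@@H](C)Oc2c(N)ncc3c(-c4cnn(C5CCNCC5)c4)coc23)c1Cl`: 1600 nM
Compound 2 `C[C@@H](Oc1c(N)ncc2c(-c3ccccn3)coc12)c1c(Cl)ccc(F)c1Cl`: 4600 nM

In a functional assay on MKN-45 cells (Homo sapiens) for antiproliferative activity, read by CellTiter-Glo, with a stated time of 3 days (a lower number here means a stronger inhibitor, a higher number a weaker inhibitor), compound 2 stands highest of the two, at 4600 nM, and its gap to compound 1 lies beyond the scatter. Compound 3 `C[C@@H](Oc1c(N)ncc2c(C3CCNCC3)coc12)c1c(Cl)ccc(F)c1Cl` carries piperidin-4-yl in place of pyridin-2-yl on an aromatic carbon. Going by the values given here, no measured step between single-place analogues is available as a guide. Compound 1, which also holds a piperidin-4-yl group, gives 1600 nM, so a small move to a lower number is expected in this assay, within the scatter: the expected change is a 1.8-fold lower number from compound 2 to compound 3 (0.26 log units; within the scatter). Compound 3 is estimated at 2500 nM, with an expected range of 700 nM to 9000 nM.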

Compound 3, half-maximal inhibitory concentration: 3100 nM
For compound 3 the middle estimate is 1.2-fold (0.09 log units) below the measured one, within the range that was stated.
By their numbers in this assay, from the lowest: compounds 1, 3 and 2 (each within the scatter of the next, the first and the last beyond it).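

In this assay, going by these compounds alone, piperidin-4-yl in place of pyridin-2-yl gives a 1.5-fold lower number from compound 2 to compound 3 (0.17 log units; within the scatter) and is the first single-place step at this aromatic carbon. On this carbon, the six-membered non-aromatic ring with its hydrogen-bond donor therefore cannot be told apart from the six-membered aromatic ring. No measurement at hand offers a reason for this result.

Still open, on these data alone, is how a morpholine, a carboxylic acid or a longer chain would read on this carbon. The step also leaves open whether a methylated piperidine nitrogen would keep the same reading.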